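Swapping chloro for methyl on a weakly active pyrazoline series

The source may hold more compounds than are shown below. What is called first, only, known or untested is meant among the compounds shown, and "the series" means these compounds.

Measured compounds in a functional assay on A-375 cells (Homo sapiens) for antiproliferative activity, read by MTT assay, with a stated time of 72 h; on this read-out higher numbers stand for weaker inhibition and lower numbers for stronger inhibition:
- compound 1, `Fc1ccc(-c2csc(N3N=C(c4ccc(N5CCCCC5)cc4)CC3c3ccc(Cl)cc3)n2)cc1`: 71400 nM
- compound 2, `Clc1ccc(-c2csc(N3N=C(c4ccc(N5CCCCC5)cc4)CC3c3ccc(Cl)cc3)n2)cc1`: > 100000 nM
- compound 3, `FC(F)(F)c1ccc(-c2csc(N3N=C(c4ccc(N5CCCCC5)cc4)CC3c3ccc(Cl)cc3)n2)cc1`: 64200 nM

From the compounds shown here alone, compound 2 gives only a limit of this assay, > 100000 nM, not a number; this is the limit of > 100000 nM in this assay, at which 1 of the 3 values shown sits, so where it stands exactly is unknown. Compound 4, `Cc1ccc(-c2csc(N3N=C(c4ccc(N5CCCCC5)cc4)CC3c3ccc(Cl)cc3)n2)cc1`, is not yet measured. The change from compound 2 to compound 4 is methyl in place of chloro on an aromatic carbon.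

For the measured compounds named here, two measured steps touch the same position. Going an at least 1.4-fold higher number from compound 1 to compound 2 (0.14 log units; that floor lies within the scatter) and an at least 1.5-fold lower number from compound 2 to compound 3 (0.19 log units; that floor lies within the scatter), while a 1.1-fold lower number from compound 1 to compound 3 (0.05 log units; within the scatter). All three measured compounds sit at the weak end, and the two steps that involve compound 2 are only floors, so no substituent at this position has moved the number beyond the scatter.

Methyl is therefore expected to behave like the other groups tried here, giving a number near the others or again a limit. The expected step is an at least 1.2-fold lower number from compound 2 to compound 4 (0.09 log units; that floor lies within the scatter). Compound 4 is estimated at 80000 nM, with a range from 40000 nM to 200000 nM.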

Compound 4, half-maximal inhibitory concentration: > 100000 nM
Compound 4 ended at the assay's limit; the forecaster's own chance of this, stated with the estimate: 35%; middle value at least 1.2-fold (0.09 log units) away from the limit.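

Methyl, on an aromatic carbon para to a large group, gives compound 4 a result in this assay that is a limit of the assay and not a number, so the step between chloro and methyl cannot be read. The comparisons that can be read give only floors, an at least 1.5-fold higher number from compound 3 to compound 4 (0.19 log units; that floor lies within the scatter) and an at least 1.4-fold higher number from compound 1 to compound 4 (0.14 log units; that floor lies within the scatter), so methyl is not shown to differ from trifluoromethyl or fluoro. The new finding is that the chloro compound is no longer alone at the limit of this small set: the limit of > 100000 nM in this assay, at which 2 of the 4 values shown sit.

From the compounds shown here alone, whether any group at this position can bring the number down beyond the scatter stays open, since these four substituents all leave the series at the weak end. An amine, a hydroxyl or a carboxylic acid in this place could begin to answer that.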